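Swapping methoxy for methyl: expected cytotoxicity of compound 3

The source may hold more compounds than are shown below. What is called first, only, known or untested is meant among the compounds shown, and "the series" means these compounds.

In an ADME assay on Vero cells (Chlorocebus sabaeus) for cytotoxicity, read by WST assay, tested at 50 ug/mL (on this read-out higher numbers stand for a weaker effect at the one concentration tested and lower numbers for a stronger effect), two compounds have been measured so far:
Compound 1 `COC(=O)c1coc(/C=C/c2ccc(F)cc2)n1` gives 102%.
Compound 2 `COC(=O)c1coc(/C=C/c2ccc(OC)cc2)n1` gives 99.6%.

Compound 2 holds the lower of the two numbers, with compound 1 nearest to it, and the gap between them lies within the scatter. Among the measured compounds shown here, the single measured step, a number 2.4 percentage points lower from compound 1 to compound 2 (within the scatter), is a methoxy in place of fluoro on an aromatic carbon at the same place that is now changed again. Compound 3 `COC(=O)c1coc(/C=C/c2ccc(C)cc2)n1` is the next compound, differing from compound 2 as follows: methyl in place of methoxy on an aromatic carbon. For the measured compounds named here, because the one step at this place, a number 2.4 percentage points lower from compound 1 to compound 2 (within the scatter), stayed within the scatter, exchanging the group there once more is expected to leave the number essentially unchanged. Compound 3 is therefore expected to give about 100%, with a range of 90% to 108%. The step from compound 2 to compound 3 is expected to be a number 0.4 percentage points higher from compound 2 to compound 3 (within the scatter), nothing beyond the scatter.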

Compound 3, a percentage reported as activity, at one concentration (the size of the read-out at that concentration, not a potency): 102%
Beside the measured number, compound 3's estimate is 2 percentage points below it; the measured number falls inside the stated range.
By their numbers in this assay, from the lowest: compounds 2, 1 and 3 (each within the scatter of the next).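

In this assay, placing methyl on this aromatic carbon, para to a large group, gives a number 2.4 percentage points higher from compound 2 to compound 3 (within the scatter) and no change at the digits printed from compound 1 to compound 3 (within the scatter). Fluoro, methoxy and methyl therefore all read alike within the scatter at this position, and this now includes a pair that differs in hydrogen-bond acceptors, with 1 on methoxy and 0 on methyl. Nothing available here gives a reason for this likeness.

The compounds shown leave open whether an amine, a carboxylic acid or a longer chain at this position would also stay within the scatter of these three. They also leave open how this assay would read for changes elsewhere on the shared core, or for any of these compounds at other concentrations.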